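The compounds below may be only part of what the source reports. "The series", "measured", "known", "first", "only" and "open" are said of these compounds alone.

Among the measured compounds shown here, compound 2 `COc1cc(-c2nn(-c3cccc(NC(=O)Nc4ccc(Cl)c(C(F)(F)F)c4)c3)cc2-c2ccncc2)ccc1Cl` stands lowest of the two numbers measured so far in a functional assay on SK-MEL-5 cells (Homo sapiens) for inhibition, read by sulforhodamine B assay, with a stated time of 48 h; on this read-out lower numbers stand for stronger inhibition of growth and higher numbers for weaker inhibition of growth: compound 2 gives 2890 nM, and its nearest neighbour compound 1 `COc1cc(-c2nn(-c3cccc(NC(=O)c4ccc(Cl)c(C(F)(F)F)c4)c3)cc2-c2ccncc2)ccc1Cl` gives 6870 nM. For the measured compounds named here, the one measured step is a 2.4-fold lower number from compound 1 to compound 2 (0.38 log units; beyond the scatter). Compound 3 `COc1cc(-c2nn(-c3cccc(NC(=O)c4ccccc4)c3)cc2-c2ccncc2)ccc1Cl` is the next compound to be measured. Its change from compound 2 is phenyl in place of (4-chloro-3-(trifluoromethyl)phenyl)amino on a carbonyl carbon. Going by the values given here, the step from compound 1 to compound 2 bears on it in reverse, since removing the amino from the carbonyl carbon undoes that change; the further loss of chloro and trifluoromethyl has no measured counterpart, so its effect is unknown. A higher number than compound 2 is therefore expected, of roughly the size seen between compound 1 and compound 2 or somewhat more, with wide uncertainty. For compound 3 the estimate is 9000 nM, with a range of 3000 nM to 30000 nM, meaning an expected step of a 3.1-fold higher number from compound 2 to compound 3 (0.49 log units; beyond the scatter).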

Compound 3, concentration for total growth inhibition: 1380 nM
The estimate for compound 3 lay 6.5-fold (0.81 log units) above the measured number; the whole stated range lies above it.
By their numbers in this assay, from the lowest: compound 3; then compound 2; then compound 1.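

In this assay the bare phenyl on the carbonyl carbon gives a 2.1-fold lower number from compound 2 to compound 3 (0.32 log units; beyond the scatter) and also a 5.0-fold lower number from compound 1 to compound 3 (0.70 log units; beyond the scatter) and so places compound 3 lowest of the three. Among these compounds, the 4-chloro-3-(trifluoromethyl)phenyl group is therefore not required for growth inhibition at this position. Removing the amino from the carbonyl carbon did not by itself set the outcome, as the simultaneous loss of chloro and trifluoromethyl goes with a lower number here, and nothing available explains the direction of these steps.

Chloro and trifluoromethyl appear only together, so their separate contributions remain unresolved, as does the effect of a plain phenylamino group on the carbonyl carbon. Also open, from the compounds shown here alone, is how a cyclohexyl ring in place of the phenyl, or a carboxylic acid or dimethylamino group on it, would behave.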